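The source may hold more compounds than are shown below. What is called first, only, known or untested is meant among the compounds shown, and "the series" means these compounds.

Three compounds share a core in which a three-carbon chain links two amine nitrogens, and each has been characterised in a physicochemical assay for acid dissociation. Compound 1, `COc1ccc(F)cc1CNCCCNc1ccnc2cc(Cc3ccc(C#N)cc3)ccc12`, gives 9.47 in this assay. Compound 2, `COc1ccc(F)cc1CNCCCNc1ccnc2cc(-c3cccc4ccccc34)ccc12`, differs from compound 1 by naphthalen-1-yl in place of 4-cyanobenzyl on an aromatic carbon, and in this assay compound 2 gives 9.47. That change made a step of no change at the digits printed from compound 1 to compound 2 (within the scatter). Compound 3, `N#Cc1ccc(Cc2ccc3c(NCCCNCc4ccco4)ccnc3c2)cc1`, carries a different core: the difference from compound 1 is furan-2-yl in place of 5-fluoro-2-methoxyphenyl on a saturated chain carbon bound to an amine nitrogen. In this assay compound 3 gives 9.47, so the step from compound 1 to compound 3 was no change at the digits printed from compound 1 to compound 3 (within the scatter).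

Compound 4, `c1coc(CNCCCNc2ccnc3cc(-c4cccc5ccccc45)ccc23)c1`, awaits measurement in this assay. It differs from compound 3 by naphthalen-1-yl in place of 4-cyanobenzyl on an aromatic carbon. This is the same change as the one from compound 1 to compound 2, made at the same place on the aromatic core, and it appears twice among these four compounds. The expected step from compound 3 to compound 4 is no change at the digits printed from compound 3 to compound 4 (within the scatter), an expectation that rests on the step of no change at the digits printed from compound 1 to compound 2 (within the scatter), the only earlier occurrence of this change. The other change seen here, from compound 1 to compound 3, also gave no change at the digits printed from compound 1 to compound 3 (within the scatter), so nothing among these compounds points to a shift. For compound 4 in this assay the estimate is 9.47, with most repeat measurements expected to fall between 9.2 and 9.75.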

Compound 4, acid dissociation constant: 9.47
For compound 4 middle estimate and measured number coincide at the digits printed; measured number inside the range.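

In this assay, placing naphthalen-1-yl where 4-cyanobenzyl stood on the core bearing furan-2-yl gave no change at the digits printed from compound 3 to compound 4 (within the scatter) and the same swap on the core bearing 5-fluoro-2-methoxyphenyl gave no change at the digits printed from compound 1 to compound 2 (within the scatter) so, across these two cores, the change carried over with the same outcome; the furan-2-yl swap agrees, with no change at the digits printed from compound 2 to compound 4 (within the scatter) alongside no change at the digits printed from compound 1 to compound 3 (within the scatter) as its earlier occurrence. Among the compounds shown here, this agreement is a weak test of transfer, since it shows only that a change with no visible step on one core also had none on the other, and it does not show that a change producing a real shift would carry across in the same way, nor does it reach beyond these four compounds. No measurement shown here explains why the number stays level across all four compounds.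

The compounds shown leave open whether any change in this series moves this number at all, for example a carboxylic acid or an amine in place of 4-cyanobenzyl, or a longer chain linking the two amine nitrogens. If such a change did produce a step, a matched pair on both cores would be needed to say whether it carries from one core to the other.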